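Replacing phenylsulfonyl with (furan-2-yl)carbonyl in compound 2

The compounds below may be only part of what the source reports. "The series", "measured", "known", "first", "only" and "open" are said of these compounds alone.

In a functional assay on MKN-45 cells (Homo sapiens) for cytotoxicity (a higher number here means a weaker inhibitor, a lower number a stronger inhibitor), compound 1 `COc1ccc(S(=O)(=O)N2CCc3cccc(NC(=O)c4ccccc4)c32)cc1` gives 250 nM, while compound 2 `COc1ccc(S(=O)(=O)N2CCc3cccc(NS(=O)(=O)c4ccccc4)c32)cc1` gives 562 nM. Compound 2 therefore holds the higher of the two numbers and is the weaker inhibitor of the pair. Among the measured compounds shown here, the single structural change that separates these two gave a 2.2-fold higher number from compound 1 to compound 2 (0.35 log units; beyond the scatter), a modest change and the only measured step available.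

Compound 3 `COc1ccc(S(=O)(=O)N2CCc3cccc(NC(=O)c4ccco4)c32)cc1` is reached from compound 2 by a single change: (furan-2-yl)carbonyl in place of phenylsulfonyl on a nitrogen on an aromatic ring. In words, (furan-2-yl)carbonyl takes the place of phenylsulfonyl on a nitrogen on an aromatic ring. Like compound 1, compound 3 carries a carbonyl on that nitrogen, so the step of a 2.2-fold higher number from compound 1 to compound 2 (0.35 log units; beyond the scatter) bears on this change when read in reverse. For the measured compounds named here, no measured compound yet carries the five-membered aromatic ring, which leaves the estimate uncertain. A modest step of similar size towards a lower number is therefore expected in this assay. The expected change is a 2.4-fold lower number from compound 2 to compound 3 (0.39 log units; beyond the scatter). For compound 3 the estimated value is 230 nM, with an expected range of 70 nM to 700 nM.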

Compound 3, half-maximal inhibitory concentration: 10.7 nM
For compound 3 the middle estimate is 21-fold (1.33 log units) above the measured one; the whole stated range lies above it.
By their numbers in this assay, from the lowest: compound 3; then compound 1; then compound 2.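

In this assay, among the compounds shown here, the comparison that isolates the ring is the one with compound 1: with the carbonyl kept on the nitrogen on an aromatic ring, furan-2-yl in place of phenyl on a carbonyl carbon gives a 23-fold lower number from compound 1 to compound 3 (1.37 log units; beyond the scatter). This shows that the group on this nitrogen can move the number much further than the earlier modest step suggested, since the full change gives a 53-fold lower number from compound 2 to compound 3 (1.72 log units; beyond the scatter), and compound 3 is the strongest inhibitor of the three, with its steps to both others beyond the scatter. Nothing shown here accounts for the size of this effect, and no supporting measurement bears on it.

The compounds shown leave open whether the gain is specific to furan-2-yl or would also appear with another ring on the carbonyl carbon, such as thiophen-2-yl, furan-3-yl or pyridin-2-yl, or with a methyl group added to the furan ring. For the compounds shown here, they also leave open whether furan-2-yl would give a similar gain on a sulfonyl group, since in this set it is seen only on a carbonyl.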